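The source may hold more compounds than are shown below. What is called first, only, known or untested is meant among the compounds shown, and "the series" means these compounds.

Compound 2: `CNCCNc1cc(N2CCCc3ccc(F)cc3C2)nc2ccc(C)cc12`, 29000 nM
Compound 1: `NCCNc1cc(N2CCCc3ccccc3C2)nc2ccc(C(F)(F)F)cc12`, 6700 nM

Of the compounds shown here, two have been measured in an ADME assay on HEp-2 cells (Homo sapiens) for cytotoxicity, read by CCK-8 assay, with a stated time of 5 days; a higher number here means that more compound is tolerated, a lower number that less compound is tolerated. Compound 2 `CNCCNc1cc(N2CCCc3ccc(F)cc3C2)nc2ccc(C)cc12` gives 29000 nM in this assay, the higher of the two numbers. Compound 1 `NCCNc1cc(N2CCCc3ccccc3C2)nc2ccc(C(F)(F)F)cc12` gives 6700 nM in this assay, and the gap between these two values lies beyond the usual scatter, so more of compound 2 is tolerated than of compound 1. The two structures differ in several places at once, so no single change can be tied to that gap.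

Compound 3 `Cc1ccc2nc(N3CCCc4ccc(F)cc4C3)cc(NC3(CN)COC3)c2c1` has not yet been measured. It differs from compound 2 in one place: 3-(aminomethyl)oxetan-3-yl in place of 2-(methylamino)ethyl on a nitrogen on an aromatic ring. Among the compounds with values here, no measured pair shows this change, so its effect cannot be read from the measured compounds. The step is expected to be a 1.2-fold lower number from compound 2 to compound 3 (0.06 log units; within the scatter), that is, no change beyond the scatter in either direction. Compound 3 is therefore estimated at 25000 nM, within a range from 8000 nM to 70000 nM.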

Compound 3, half-maximal cytotoxic concentration: 86000 nM
Estimate against measurement, compound 3: 3.4-fold (0.54 log units) below, outside the stated range (above it).
By their numbers in this assay, from the lowest: compound 1; then compound 2; then compound 3.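

Within the data shown here, replacing 2-(methylamino)ethyl with 3-(aminomethyl)oxetan-3-yl on this nitrogen gives a 3.0-fold higher number from compound 2 to compound 3 (0.47 log units; beyond the scatter) in this assay and is the first change at a single place in this set. It shows that the group at this position can shift the number beyond the scatter, here towards more compound being tolerated. Nothing available explains why the number rises.

The entering group adds a four-membered non-aromatic ring with one hetero atom, and these compounds cannot separate the effect of that ring from the effect of its oxygen; a four-membered all-carbon ring carrying the same aminomethyl group would address that question. As far as these compounds go, whether the same swap gives a similar step on the core of compound 1 also remains open.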